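Aryl swap on the biaryl of compound 1

The source may report more compounds than this note shows. Statements on the series, on what has been measured and on what is new or still open speak of the compounds shown alone.

Measured so far in a physicochemical assay for lipophilicity, read by HPLC, at pH 7.5; on this read-out higher numbers stand for higher lipophilicity and lower numbers for lower lipophilicity:
compound 1, `CC[C@@H](Nc1c(C#N)c(-c2ccc(-c3cccc(C)c3F)cc2)nc2cnccc12)C(N)=O`: 3
compound 2, `CC[C@@H](Nc1c(C#N)c(-c2ccc(-c3cccc(C)c3F)cc2)nc2cnccc12)C(=O)O`: 2.1

Compound 1 holds the higher of the two numbers; compound 2 sits a number 0.90 log units lower from compound 1 to compound 2 (beyond the scatter), a change at the carbonyl carbon at the far end of the chain, well clear of the biaryl.

Compound 3, `CC[C@@H](Nc1c(C#N)c(-c2ccc(-c3cccc(OC)c3)cc2)nc2cnccc12)C(N)=O`, is the next member. Its change from compound 1 is 3-methoxyphenyl in place of 2-fluoro-3-methylphenyl on an aromatic carbon. Going by the values given here, no measured pair touches this position: the only step known, from compound 1 to compound 2, alters the carbonyl substituent, so it says nothing about exchanging one aryl for another and gives no scale to borrow from.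

The expectation therefore rests on the structural change alone, read against compound 1 at 3. A fluorine and a methyl leave and a methoxy enters, bringing one hydrogen-bond acceptor where there was none. Among the compounds with values here, on that basis a modest decrease in this assay is expected, a number 0.70 log units lower from compound 1 to compound 3 (beyond the scatter), of a size comparable to the one measured step but not derived from it. Compound 3 is estimated at 2.3, with a range from 1.8 to 2.8.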

Compound 3, distribution coefficient: 2.7
For compound 3 the middle estimate is 0.40 log units below the measured one; low and high end bracket the measured number.
By their numbers in this assay, from the lowest: compound 2; then compounds 3 and 1 (each within the scatter of the next).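

Going by these compounds alone, the first reading at this position, on the aryl group para to a large group, comes from exchanging 2-fluoro-3-methylphenyl for 3-methoxyphenyl. In this assay, within the data shown here, this exchange gives a number 0.30 log units lower from compound 1 to compound 3 (within the scatter), so the two aryl groups, with equal heavy-atom counts and one hydrogen-bond acceptor entering, cannot be told apart on this read-out, whereas the carbonyl change gives a number 0.90 log units lower from compound 1 to compound 2 (beyond the scatter) and remains the only step beyond the scatter. No separate measurement is available to account for either step.

Because the fluorine, the methyl and the methoxy change together in one exchange, their separate contributions remain unresolved, and 3-methylphenyl or 2-fluorophenyl on the same core would be needed to separate them. Going by these compounds, it also remains open whether this flat reading extends to a more different aryl group, such as a pyridyl or a 3-trifluoromethoxyphenyl, or whether it holds with a carboxylic acid in place of the primary amide.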